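Three Esters at One Reading, a Fourth Awaited

The source may report more compounds than this note shows. Statements on the series, on what has been measured and on what is new or still open speak of the compounds shown alone.

Compound 1 `COc1cc(OC)c(OC)cc1/C=C/COC(=O)/C=C/c1c(OC)ccc(OC)c1OC` gives 100% in a functional assay on the whole organism (strain Kunming) with Mus musculus as the target, with a stated time of 0.5 h, at a dose of 100 mg/kg by the intraperitoneal route; on this read-out lower numbers stand for a stronger effect and higher numbers for a weaker effect at the one dose given. Compound 2 `COc1cc(OC)c(OC)cc1/C=C/COC(=O)/C=C/c1ccc(F)cc1` gives 100% in this assay. Compound 3 `COc1cc(OC)c(OC)cc1/C=C/COC(=O)/C=C/c1ccc(Br)cc1` gives 100% in this assay.

Compound 2 sits level with compounds 1 and 3, all three at the same reading within the scatter. Compound 4 `COc1cc(OC)c(OC)cc1/C=C/COC(=O)/C=C/c1ccccc1Cl` differs from compound 2 by 2-chlorophenyl in place of 4-fluorophenyl on a double-bonded chain carbon bound to a double-bonded chain carbon. Among the measured compounds shown here, the one step that bears on this, no change at the digits printed from compound 2 to compound 3 (within the scatter), exchanged one halogen for another on the ring and moved nothing. For the measured compounds named here, no measured pair shifts the halogen's place on the ring, so that part of the change is untested. Given that every measured compound shares one reading, compound 4 is expected to show no change at the digits printed from compound 2 to compound 4 (within the scatter) in this assay. Compound 4 is estimated at 100%, between 85% and 100%.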

Compound 4, a percentage reported as activity, at one dose (the size of the read-out at that dose, not a potency): 100%
The estimate for compound 4 equals the measured number at the digits printed; the measured number falls inside the stated range.
By their numbers in this assay, from the lowest: compounds 1, 2, 3 and 4 (each within the scatter of the next).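

In this assay, the step to 2-chlorophenyl from 4-fluorophenyl gives no change at the digits printed from compound 2 to compound 4 (within the scatter), and the step to it from 4-bromophenyl gives no change at the digits printed from compound 3 to compound 4 (within the scatter). This position on the double-bonded chain therefore tolerates a change in both the halogen and its place on the ring with no shift in the reading, although these two changes are made together and cannot be separated here. Nothing shown offers an explanation for this flat result.

From the compounds shown here alone, whether an amine or a carboxylic acid on the phenyl ring would move the reading remains open. So does the reading of 4-chlorophenyl, which would separate the halogen's identity from its place.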